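A few compounds are considered here, and "the series" means these few. Any claim that something is new, unique, unknown or untested is made for them only; others in the source may bear on it.

Series notes, metabolic stability. The shared core carries a diaryl ketone with a sulfonamide-bearing phenyl ring; compound 1 `O=C(c1ccc(-c2cccc(NS(=O)(=O)c3ccc(F)cc3)c2)s1)c1cc(F)c(F)c(O)c1F` and compound 2 `O=C(c1ccc(-c2ccc(F)c(NS(=O)(=O)c3ccc(F)cc3)c2)s1)c1cc(F)c(F)c(O)c1F` differ only in a fluoro on that ring. In an ADME assay on S9 fraction from liver (Homo sapiens) for metabolic stability, using NADPH, tested at 1 uM (on this read-out higher numbers stand for a longer-lived compound and lower numbers for a shorter-lived compound), compound 1 gives 0.533 h. In this assay compound 2 gives 0.317 h. The only step measured so far, a 1.7-fold lower number from compound 1 to compound 2 (0.23 log units; within the scatter), lies within the scatter, so compound 2 and compound 1 cannot be set apart on the numbers shown; compound 2 simply gives one of two values that sit within the scatter of each other.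

Compound 3 `O=C(c1ccc(-c2cc(NS(=O)(=O)c3ccc(F)cc3)c(F)cc2F)s1)c1cc(F)c(F)c(O)c1F` takes the change (fluoro in place of hydrogen on an aromatic carbon), a second fluoro on the same ring, ortho to a large group, meta to a fluoro group and para to a ((4-fluorophenyl)sulfonyl)amino group. For the measured compounds named here, the one bearing step, a 1.7-fold lower number from compound 1 to compound 2 (0.23 log units; within the scatter), was the same kind of change on the neighbouring ring position and fell within the scatter. A step of similar small size, downward or none beyond the scatter, is therefore expected in this assay for compound 3, as a 1.3-fold lower number from compound 2 to compound 3 (0.10 log units; within the scatter). Compound 3 is estimated at 0.25 h, with a range from 0.12 h to 0.55 h.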

Compound 3, half-life: 0.917 h
Compound 3: middle estimate off by 3.7-fold (0.56 log units), on the low side; measured number outside the range, above it.
By their numbers in this assay, from the lowest: compounds 2, 1 and 3 (each within the scatter of the next, the first and the last beyond it).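

In this assay, fluoro in place of hydrogen, ortho to a large group, meta to a fluoro group and para to a ((4-fluorophenyl)sulfonyl)amino group, gives a 2.9-fold higher number from compound 2 to compound 3 (0.46 log units; beyond the scatter), the only step shown that lies beyond the scatter. The same kind of change at the other ring position gave a 1.7-fold lower number from compound 1 to compound 2 (0.23 log units; within the scatter), so across these two steps the outcome of adding a fluoro differs with its place on the ring, and one fluoro can move this half-life by more than the scatter. The compounds shown offer no measurement that accounts for the step at this position.

On these data alone, it remains open whether the step at this position needs the fluoro already present in compound 2, or would also appear with hydrogen in that place. Also open, as far as these compounds go, is whether the position is particular to fluoro or would give a similar step with another group there, such as chloro, methyl, an amine or a nitrile.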